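This account rests on a few compounds, and the source may have more. Where it says the series, first, only, none or still open, it means among the compounds named here.

Compound 1 `CC1=C(C(=O)OCCC2CCN(C(=O)OC(C)(C)C)CC2)C(c2cccc(Br)c2)C2=C(CC(C)(C)CC2=O)N1`: 2950 nM
Compound 2 `CC1=C(C(=O)OCC2CCN(C(=O)OC(C)(C)C)CC2)C(c2cccc([N+](=O)[O-])c2)C2=C(CC(C)(C)CC2=O)N1`: > 10000 nM
Compound 3 `CC1=C(C(=O)OCC2CCN(C(=O)OC(C)(C)C)CC2)C(c2cccc(C#N)c2)C2=C(CC(C)(C)CC2=O)N1`: 220 nM

All three were tested in an assay on HEK293 cells for inhibition of neurogenic locus notch homolog protein 1 (Homo sapiens), read by a luciferase reporter and resazurin assay, with a stated time of 16 h; a lower number here means a stronger inhibitor, a higher number a weaker inhibitor. The value of compound 2 is a limit of the assay, not a number (the limit of > 10000 nM in this assay, at which 1 of the 3 values shown sits). Of the two numbers shown, compound 3 gives the lowest, and compound 1 a higher one. Compound 4 `CC1=C(C(=O)OCC2CCN(C(=O)OC(C)(C)C)CC2)C(c2ccc3c(c2)OCCO3)C2=C(CC(C)(C)CC2=O)N1` differs from compound 3 by 2,3-dihydro-1,4-benzodioxin-6-yl in place of 3-cyanophenyl on a saturated ring carbon. Among the compounds with values here, only one measured step alters the group on this same saturated ring carbon: an at least 45-fold lower number from compound 2 to compound 3 (1.65 log units; beyond the scatter), and it shows that what sits there can move the number a great deal. Nothing measured tells how the new ring compares with cyano, so a step toward weaker inhibition of moderate size is expected, a 4.5-fold higher number from compound 3 to compound 4 (0.66 log units; beyond the scatter), with wide uncertainty. Compound 4 is therefore estimated at 1000 nM, between 150 nM and 7000 nM.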

Compound 4, half-maximal inhibitory concentration: 1520 nM
For compound 4 the middle estimate is 1.5-fold (0.18 log units) below the measured one, within the range that was stated.
By their numbers in this assay, from the lowest: compound 3; then compounds 4 and 1 (each within the scatter of the next). At a limit, above all of these: compound 2.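

The group on this saturated ring carbon need not carry a nitrile to give a measurable number: 2,3-dihydro-1,4-benzodioxin-6-yl in place of 3-nitrophenyl gives an at least 6.5-fold lower number from compound 2 to compound 4 (0.81 log units; beyond the scatter). Compound 2 stands at a limit of the assay, not a number: the limit of > 10000 nM in this assay, at which 1 of the 4 values shown sits. Replacing 3-cyanophenyl with the same fused group still gives a 6.9-fold higher number from compound 3 to compound 4 (0.84 log units; beyond the scatter), so 3-cyanophenyl remains the best of these three groups.

As far as these compounds go, whether 3-aminophenyl or 3-carboxyphenyl would come close to 3-cyanophenyl stays open. Also open, from the compounds shown here alone, is which part of the new group matters, since its two oxygens and second ring enter together.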